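Anilide replacement of the benzylsulfonyl in a pyridopyrimidinone series

The compounds below may be only part of what the source reports. "The series", "measured", "known", "first", "only" and "open" are said of these compounds alone.

Measured compounds:
- compound 1 `Cn1c(=O)c(S(=O)(=O)c2ccc(F)cc2[N+](=O)[O-])cc2cnc(Nc3ccc4[nH]ccc4c3)nc21`: 1500 nM
- compound 2 `Cn1c(=O)c(S(=O)(=O)Cc2ccc(F)cc2)cc2cnc(Nc3ccc4[nH]ccc4c3)nc21`: 30000 nM
- compound 3 `Cn1c(=O)c(S(=O)(=O)c2ccc(C(=O)O)cc2)cc2cnc(Nc3ccc4[nH]ccc4c3)nc21`: 10000 nM

In a functional assay on DU-145 cells (Homo sapiens) for inhibition, read by trypan blue exclusion, with a stated time of 72 h (on this read-out lower numbers stand for stronger inhibition and higher numbers for weaker inhibition), compound 2 gives the highest number of the three, with compound 3 nearest and compound 1 furthest; the steps to both lie beyond the scatter, so compound 2 is the weakest measured member of the set.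

The unmeasured compound 4 `Cn1c(=O)c(C(=O)Nc2ccc(F)cc2)cc2cnc(Nc3ccc4[nH]ccc4c3)nc21` differs from compound 2 as follows: (4-fluorophenyl)carbamoyl in place of (4-fluorobenzyl)sulfonyl on an aromatic carbon

The measured steps speak only to the group on the sulfonyl sulfur: a 20-fold higher number from compound 1 to compound 2 (1.30 log units; beyond the scatter) and a 3.0-fold lower number from compound 2 to compound 3 (0.48 log units; beyond the scatter), both returning a lower number than compound 2 when a ring carbon rather than a benzyl carbon sits on that sulfur. For the measured compounds named here, no measured pair replaces the sulfonyl group itself, so the step to compound 4 is not directly covered. Given that compound 2 is the weakest point measured in this assay and that the entering group again attaches a ring carbon directly to the connecting unit, a modestly lower number is expected, with wide uncertainty.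

Compound 4 is expected to give 8000 nM in this assay, with a range of 1500 nM to 40000 nM. This amounts to an expected step of a 3.8-fold lower number from compound 2 to compound 4 (0.57 log units; beyond the scatter).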

Compound 4, half-maximal inhibitory concentration: 5000 nM
The estimate for compound 4 lay 1.6-fold (0.20 log units) above the measured number; low and high end bracket the measured number.
By their numbers in this assay, from the lowest: compound 1; then compounds 4 and 3 (each within the scatter of the next); then compound 2.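

For the compounds shown here, the step of a 6.0-fold lower number from compound 2 to compound 4 (0.78 log units; beyond the scatter) in this assay is the first to change the connecting unit itself, as the earlier steps only varied the group on the sulfonyl sulfur; it shows that this aromatic carbon does not need a sulfonyl group to give a lower number than compound 2. With (4-fluorophenyl)carbamoyl at this position, compound 4 at 5000 nM sits within the scatter of compound 3 at 10000 nM, while compound 1 keeps the lowest number in the series at 1500 nM. Nothing available explains the size of this step.

The step changes the connecting unit and removes the benzyl carbon in a single move, so the share of each stays unresolved; a (4-fluorobenzyl)carbamoyl group or a (4-fluorophenyl)sulfonyl group at this position would separate the two. Also open, as far as these compounds go, are the role of the amide hydrogen, which an N-methyl amide would test, and whether the 4-fluoro-2-nitrophenyl group gives the same gain on a carbamoyl link as on the sulfonyl sulfur.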